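Swapping 3,4-dimethoxyphenyl for 3-bromophenyl on the carbonyl carbon

A few compounds are considered here, and "the series" means these few. Any claim that something is new, unique, unknown or untested is made for them only; others in the source may bear on it.

In a functional assay on A549 cells (Homo sapiens) for inhibition, read by MTT assay, with a stated time of 24 h (a higher number here means a weaker inhibitor of growth, a lower number a stronger inhibitor of growth), compound 1 `COc1ccc2c(c1)c(-c1nc3ccccc3n1C(=O)c1ccccc1)cn2C` gives 16700 nM while compound 2 `COc1cccc(C(=O)n2c(-c3cn(C)c4ccc(OC)cc34)nc3ccccc32)c1` gives 4600 nM and compound 3 `COc1ccc2c(c1)c(-c1nc3ccccc3n1C(=O)c1ccc(OC)c(OC)c1)cn2C` gives 2700 nM as its value. The position of compound 3 is shared: a 1.7-fold lower number from compound 2 to compound 3 (0.23 log units; within the scatter) lies within the scatter, while a 6.2-fold lower number from compound 1 to compound 3 (0.79 log units; beyond the scatter) lies beyond it. The next change leads to compound 4 `COc1ccc2c(c1)c(-c1nc3ccccc3n1C(=O)c1cccc(Br)c1)cn2C` by 3-bromophenyl in place of 3,4-dimethoxyphenyl on a carbonyl carbon on the same carbonyl carbon. For the measured compounds named here, no bromine-bearing compound has been measured, so the closest guide is the modest 3.6-fold lower number from compound 1 to compound 2 (0.56 log units; beyond the scatter) seen with one methoxy in place of hydrogen. The estimated step is a 1.9-fold higher number from compound 3 to compound 4 (0.27 log units; within the scatter) with a higher number expected but no firm move beyond the scatter. For compound 4 the expected value is 5000 nM with 1800 nM to 14000 nM as the estimated range.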

Compound 4, concentration for 50% growth inhibition: 24800 nM
The estimate for compound 4 lay 5.0-fold (0.70 log units) below the measured number; measured number above the stated range.
By their numbers in this assay, from the lowest: compounds 3 and 2 (each within the scatter of the next); then compounds 1 and 4 (each within the scatter of the next).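

Methoxy and bromo part ways on this ring: a 5.4-fold higher number from compound 2 to compound 4 (0.73 log units; beyond the scatter) in this assay for bromo in place of methoxy on an aromatic carbon, and a 9.2-fold higher number from compound 3 to compound 4 (0.96 log units; beyond the scatter) for 3-bromophenyl in place of 3,4-dimethoxyphenyl on the carbonyl carbon. Against the unsubstituted phenyl, bromo in place of hydrogen gives only a 1.5-fold higher number from compound 1 to compound 4 (0.17 log units; within the scatter) and so does not reproduce the shift seen with the methoxy compounds, compound 2 and compound 3. No evidence at hand explains this difference. Going by these compounds, whether an amine or a carboxylic acid on this ring would behave like methoxy or like bromo remains open.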